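Cyano for fluoro on the sulfonyl aryl group

This account rests on a few compounds, and the source may have more. Where it says the series, first, only, none or still open, it means among the compounds named here.

Values in a functional assay on QGY-7703 cells (Homo sapiens) for cytotoxicity, read by MTT assay, with a stated time of 24 h (on this read-out lower numbers stand for stronger inhibition and higher numbers for weaker inhibition), are as follows:
- compound 1 `N#Cc1ccc(S(=O)(=O)N2C/C(=C\c3cccnc3)C(=O)/C(=C/c3ccccc3C(F)(F)F)C2)cc1` gives 6150 nM in this read-out
- compound 2 `O=C1/C(=C/c2ccncc2)CN(S(=O)(=O)c2ccc(F)cc2)C/C1=C\c1ccccc1C(F)(F)F` gives 7700 nM in this read-out

Compound 2 stands within the scatter of compound 1 at 6150 nM and no order can be read between them. Compound 3 `N#Cc1ccc(S(=O)(=O)N2C/C(=C\c3ccncc3)C(=O)/C(=C/c3ccccc3C(F)(F)F)C2)cc1` carries cyano in place of fluoro on an aromatic carbon para to a large group, so 4-fluorophenyl becomes 4-cyanophenyl. Among the compounds with values here, no measured step covers this change, so the step expected in this assay is none beyond the scatter. The estimate means a 1.2-fold lower number from compound 2 to compound 3 (0.07 log units; within the scatter) and no change beyond the scatter is expected. For compound 3 the estimated value is 6500 nM with an expected range (from 3000 nM to 14000 nM).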

Compound 3, half-maximal inhibitory concentration: 6290 nM
Beside the measured number, compound 3's estimate is 1.0-fold (0.01 log units) above it, and the stated range covers the measured number.
By their numbers in this assay, from the lowest: compounds 1, 3 and 2 (each within the scatter of the next).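

In this assay 4-cyanophenyl in place of 4-fluorophenyl on the sulfonyl group stays within the scatter (a 1.2-fold lower number from compound 2 to compound 3 (0.09 log units; within the scatter)), so this aromatic carbon tolerates either group in this series. Pyridin-4-yl in place of pyridin-3-yl also stays within the scatter (a 1.0-fold higher number from compound 1 to compound 3 (0.01 log units; within the scatter)), so neither exchange separates these compounds. No further data bear on these results. As far as these compounds go, whether an amine or a carboxylic acid in place of the nitrile would move the number beyond the scatter stays open. So does the effect of replacing the trifluoromethyl group on the shared core.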